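Thiophene carboxamide series: urea replacing benzyl on the ring nitrogen

A few compounds are considered here, and "the series" means these few. Any claim that something is new, unique, unknown or untested is made for them only; others in the source may bear on it.

Measured so far:
- compound 1, `NC(=O)c1c(NC(=O)c2ccccc2Cl)sc2c1CCN(Cc1ccccc1)C2`: 14500 nM
- compound 2, `Cc1ccc(C(=O)Nc2sc3c(c2C(N)=O)CCN(Cc2ccc(Cl)cc2Cl)C3)cc1`: 25500 nM
- compound 3, `NC(=O)c1c(NC(=O)c2ccccc2Cl)sc2c1CCN(C(=S)Nc1cccc3ccccc13)C2`: 20700 nM

All three were run in a functional assay on MKN-74 cells (Homo sapiens) for antiproliferative activity, with a stated time of 24 h; a higher number here means a weaker inhibitor, a lower number a stronger inhibitor. Compound 1 gives the lowest number of the three, but its gaps to compound 3 and to compound 2 both sit within the scatter, so no order among them can be claimed. Compound 4, `NC(=O)c1c(NC(=O)c2ccccc2Cl)sc2c1CCN(C(=O)Nc1ccccc1Cl)C2`, has not been measured. It differs from compound 1 in one place: (2-chlorophenyl)carbamoyl in place of benzyl on an amine nitrogen in a ring. The closest analogue at this position is compound 3, whose value in this assay differs from that of compound 1 only within the scatter. On that basis the step of a 1.2-fold higher number from compound 1 to compound 4 (0.09 log units; within the scatter) is expected to be small, with no direction beyond the scatter. Compound 4 is estimated at 18000 nM, with a range of 7000 nM to 45000 nM.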

Compound 4, half-maximal inhibitory concentration: 16300 nM
Estimate against measurement, compound 4: 1.1-fold (0.04 log units) above; measured number inside the range.
By their numbers in this assay, from the lowest: compounds 1, 4, 3 and 2 (each within the scatter of the next).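

In this assay, (2-chlorophenyl)carbamoyl in place of benzyl on the amine nitrogen in a ring gives a 1.1-fold higher number from compound 1 to compound 4 (0.05 log units; within the scatter). For the compounds shown here, this is the first single-change step readable at this position: the entering group brings more heavy atoms plus a hydrogen-bond donor and acceptor, yet the step stays within the scatter. No measurement on hand accounts for this result. Still open, as far as these compounds go, is whether a carboxylic acid or a longer chain ending in an amine at this nitrogen would give a step beyond the scatter.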